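Three para-substituted pyrazole acids, all beyond the assay limit

The source may report more compounds than this note shows. Statements on the series, on what has been measured and on what is new or still open speak of the compounds shown alone.

Compound 1 `CC(C)(C)NCc1c(C(=O)O)nn(-c2ccccc2)c1-c1ccccc1` gives > 716000 nM in a functional assay on PC-3 cells (Homo sapiens) for inhibition, read by sulforhodamine B assay, with a stated time of 48 h (a higher number here means a weaker inhibitor of growth, a lower number a stronger inhibitor of growth), a limit of the assay and not a number.
Compound 2 `Cc1ccc(-c2c(CNC(C)(C)C)c(C(=O)O)nn2-c2ccccc2)cc1` gives > 688000 nM in this assay, again a limit.
Compound 3 `CC(C)(C)NCc1c(C(=O)O)nn(-c2ccc(Cl)cc2)c1-c1ccccc1` gives > 652000 nM in this assay, also a limit.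

All three measured compounds share one core and differ only in a single substituent. Compound 2 differs from compound 1 by methyl in place of hydrogen on an aromatic carbon; the corresponding step that the two limits leave unreadable from compound 1 to compound 2 cannot be read, since both ends are limits (the limit of > 716000 nM in this assay, at which 1 of the 3 values shown sits, (the limit of > 688000 nM in this assay, at which 1 of the 3 values shown sits)). Compound 3 differs from compound 1 by chloro in place of hydrogen on an aromatic carbon, and here too the step that the two limits leave unreadable from compound 1 to compound 3 is unreadable, with both values sitting at limits (the limit of > 716000 nM in this assay, at which 1 of the 3 values shown sits, (the limit of > 652000 nM in this assay, at which 1 of the 3 values shown sits)).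

Compound 4 `Cc1ccc(-c2c(CNC(C)(C)C)c(C(=O)O)nn2-c2ccc(Cl)cc2)cc1` has not yet been measured. It differs from compound 3 by methyl in place of hydrogen on an aromatic carbon, which is the same change as that from compound 1 to compound 2, at a place described in the same words. Because that earlier step that the two limits leave unreadable from compound 1 to compound 2 left compound 2 at a limit just as compound 1 was, compound 4 is expected to show a step that the limit leaves unreadable from compound 3 to compound 4 that stays near the limit. Compound 4 is therefore estimated at 800000 nM in this assay, between 250000 nM and 3000000 nM, most likely reported only as a limit.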

Compound 4, concentration for 50% growth inhibition: > 629000 nM
Compound 4: a limit, no number; the forecaster's own chance of this, stated with the estimate: 85%; the middle value does not contradict the limit.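

In this assay compound 4 gives > 629000 nM, a limit of the assay and not a number. Compound 2, compound 3 and compound 4 therefore add no readable step, as both ends of each new comparison are limits. All four compounds shown stand at limits, which leaves open whether methyl or chloro in place of hydrogen alters growth inhibition on the shared core at all.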